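The source may report more compounds than this note shows. Statements on the series, on what has been measured and on what is new or still open speak of the compounds shown alone.

Working notes on the series.

Compound 1 `O=C(/C(=C\c1ccc([N+](=O)[O-])c(O)c1)SCc1ccc(Br)cc1)c1ccc(C(F)(F)F)cc1` and compound 3 `O=C(/C(=C\c1ccc([N+](=O)[O-])c(O)c1)Sc1ccc(Br)cc1)c1c(F)c(F)c(F)c(F)c1F` share the measured end of the set, while compound 2 `O=C(/C(=C\c1ccc(O)c([N+](=O)[O-])c1)SCc1ccc(Br)cc1)c1ccc(C(F)(F)F)cc1` sits apart. In a functional assay on DU-145 cells (Homo sapiens) for inhibition, read by trypan blue exclusion, with a stated time of 96 h (on this read-out lower numbers stand for stronger inhibition of growth and higher numbers for weaker inhibition of growth), compound 1 gives 1000 nM, and compound 3 gives 1000 nM; at the digits recorded the two stand level, and together they are the lowest of the three numbers. Compound 2 gives 10000 nM in this assay.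

Among the measured compounds shown here, the one step that can be counted is the change (4-hydroxy-3-nitrophenyl in place of 3-hydroxy-4-nitrophenyl on a double-bonded chain carbon bound to a double-bonded chain carbon), which made a 10-fold higher number from compound 1 to compound 2 (1.00 log units; beyond the scatter). Compound 1 and compound 3 differ in their cores, and the difference between the two cores is not broken down here; what the pair shows is simply that the two values coincide at the digits recorded.

Compound 4 `O=C(/C(=C\c1ccc(O)c([N+](=O)[O-])c1)Sc1ccc(Br)cc1)c1c(F)c(F)c(F)c(F)c1F` has not yet been measured. It is obtained from compound 3 by 4-hydroxy-3-nitrophenyl in place of 3-hydroxy-4-nitrophenyl on a double-bonded chain carbon bound to a double-bonded chain carbon, the same change in the same place as the step from compound 1 to compound 2. With only one earlier occurrence of this change to rest on, the expectation is that it carries over: a step of about a 10-fold higher number from compound 3 to compound 4 (1.00 log units; beyond the scatter) is expected from compound 3 to compound 4, because in this assay compound 1 gives 1000 nM against compound 2 at 10000 nM. On that basis compound 4 is estimated at 10000 nM in this assay. On these data alone, the range 3000 nM to 30000 nM is the expected spread for compound 4, reflecting that the transfer of the step to a different core is untested.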

Compound 4, concentration for 50% growth inhibition: 1000 nM
For compound 4 the middle estimate is 10-fold (1.00 log units) above the measured one; measured number outside the range, below it.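

In this assay the change did not carry over from one core to the other: the new step reads no change at the digits printed from compound 3 to compound 4 (within the scatter), so the drop seen on the core of compound 1 does not appear on the core of compound 3, and the two steps do not agree: the same change on two cores in this assay, a 10-fold higher number (1.00 log units; beyond the scatter) from compound 1 to compound 2 and no change at the digits printed (within the scatter) from compound 3 to compound 4, 10-fold (1.00 log units) apart, beyond the scatter of two such steps

For this series, then, the size of the step from 3-hydroxy-4-nitrophenyl to 4-hydroxy-3-nitrophenyl cannot be read as a fixed increment that transfers between cores, and the pair of steps counts against using one as a forecast for the other. It does not show which feature of the cores separates the two outcomes, since the core of compound 1 and the core of compound 3 differ in more than one place, and one pair on each core gives no reason for the difference.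

Still open, on these data alone, is how the step behaves on a core that carries only one of those differences, which would show which of them goes with the larger step. Also open, as far as these compounds go, is whether either ring pattern holds its place when the nitro group gives way to an amine or a carboxylic acid.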